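A few compounds are considered here, and "the series" means these few. Any claim that something is new, unique, unknown or untested is made for them only; others in the source may bear on it.

Working notes on the series

Of the compounds shown here, three have been measured in a physicochemical assay for lipophilicity, in phosphate buffer, measured as octanol-water partition; a lower number here means a more polar compound, a higher number a more lipophilic compound. Compound 1 `Cc1nc2ccccc2c(=O)n1/N=C/c1ccc(Oc2ccccc2)cc1` gives 4.01 in this assay. Compound 2 `O=c1c2ccccc2nc(-c2ccccc2)n1/N=C/c1ccc(Oc2ccc([N+](=O)[O-])cc2)cc1` gives 6.12 in this assay. Compound 3 `O=c1c2ccccc2nc(-c2ccccc2)n1/N=C/c1ccc(Oc2ccccc2)cc1` gives 6.13 in this assay.

Compound 3 and compound 1 differ in one place: methyl in place of phenyl on an aromatic carbon. That change made a number 2.12 log units lower from compound 3 to compound 1 (beyond the scatter).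

Compound 3 and compound 2 differ in one place: nitro in place of hydrogen on an aromatic carbon. That change made a number 0.01 log units higher from compound 2 to compound 3 (within the scatter), so the nitro group as such leaves the partition coefficient where it was, within the usual scatter.

Compound 4 `Cc1nc2ccccc2c(=O)n1/N=C/c1ccc(Oc2ccc([N+](=O)[O-])cc2)cc1` has not yet been measured in this assay. It differs from compound 2 in one place: methyl in place of phenyl on an aromatic carbon. Among the compounds with values here, this is the same kind of change as the one from compound 3 to compound 1, and the surroundings of the place are described in the same words for both pairs, so the two changes are treated as the same change made on two cores that differ only by the nitro group.

For compound 4 the step from compound 2 is therefore expected to be about as large as the measured one, since the cores of compound 2 and compound 3 gave values within the scatter of each other (a number 0.01 log units higher from compound 2 to compound 3 (within the scatter)); the expected step is a number 2.12 log units lower from compound 2 to compound 4 (beyond the scatter). Compound 4 is accordingly estimated at 4 in this assay, with a range from 3.5 to 4.5.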

Compound 4, partition coefficient: 4.01
Beside the measured number, compound 4's estimate is 0.01 log units below it; the measured number falls inside the stated range.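

In this assay, the replacement of phenyl by methyl on the aromatic carbon between two ring nitrogen atoms carries over from one core to the other: the step of a number 2.11 log units lower from compound 2 to compound 4 (beyond the scatter) stands alongside the earlier step of a number 2.12 log units lower from compound 3 to compound 1 (beyond the scatter), both large, and the nitro group also shows no separation on the methyl-bearing core, with no change at the digits printed from compound 1 to compound 4 (within the scatter) in the new pair. This is one transfer only, across two cores that differ solely by the nitro group, so it shows that the step holds for this pair of cores and does not show that it would hold on a core changed in any other way. Nothing at hand bears on why the step keeps its size or why the nitro group leaves the values level, and the numbers alone give no reason for either.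

The compounds shown carry only phenyl or methyl at this place, and only hydrogen or nitro on the far ring, so it stays open whether a longer chain such as butyl, or an amine, would fall on the same line between the two values at this place. Going by these compounds, it also stays open whether the step would keep its size with a carboxylic acid in place of the nitro group.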